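Replacing dimethylamino on a carbonyl carbon in compound 2

A few compounds are considered here, and "the series" means these few. Any claim that something is new, unique, unknown or untested is made for them only; others in the source may bear on it.

Within the data shown here, in an in vivo functional assay on the whole organism for inhibition, with Rattus norvegicus as the target (a higher number here means that more compound is needed for the effect, a lower number that less compound is needed), compound 2 (`CCCCc1nc(C)c(CC(=O)N(C)C)c(=O)n1Cc1ccc(-c2ccccc2-c2nnn[nH]2)cc1`) gives 0.018 mg/kg, the only number available in this small set. Compound 1 (`CCCc1nc(C)c(CC(=O)O)c(=O)n1Cc1ccc(-c2ccccc2-c2nnn[nH]2)cc1`) stands at "not determined" (no result reported), and compound 3 (`CCCc1nc(C)c(CC(=O)N(CC)CC)c(=O)n1Cc1ccc(-c2ccccc2-c2nnn[nH]2)cc1`) stands at "not determined" (no result reported), so neither offers a comparison. Compound 4 (`CCCCc1nc(C)c(CC(=O)N2CCC[C@H]2C(=O)OC)c(=O)n1Cc1ccc(-c2ccccc2-c2nnn[nH]2)cc1`) carries 2-(methoxycarbonyl)pyrrolidin-1-yl in place of dimethylamino on a carbonyl carbon. Among the measured compounds shown here, no measured pair shows what such a change does in this assay, so the expectation rests on the structural change alone. A small rise in the dose needed is expected, an estimated step of a 2.2-fold higher number from compound 2 to compound 4 (0.35 log units; beyond the scatter). Compound 4 is expected at 0.04 mg/kg, with an estimated range from 0.008 mg/kg to 0.2 mg/kg.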

Compound 4, dose for half-maximal effect: 0.043 mg/kg
The estimate for compound 4 lay 1.1-fold (0.03 log units) below the measured number, within the range that was stated.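

In this assay this position on a carbonyl carbon takes the ring-bearing 2-(methoxycarbonyl)pyrrolidin-1-yl group in place of dimethylamino, at a modest cost: a 2.4-fold higher number from compound 2 to compound 4 (0.38 log units; beyond the scatter). This is the first measured change at this position, and the compounds shown offer no measured property that accounts for it. They leave open whether the ring or the methoxycarbonyl group drives the step. A plain pyrrolidin-1-yl group, or a carboxylic acid in place of the methyl ester, would separate the two.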